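Shortening the side chain of compound 1

The source may report more compounds than this note shows. Statements on the series, on what has been measured and on what is new or still open speak of the compounds shown alone.

Compound 1 `N=C(S)CCCCn1nc(-c2ccccc2)ccc1=O` carries the shared core with a chain of four saturated carbons before the terminal group. In a functional assay on the whole organism (stomach) with Rattus norvegicus as the target (on this read-out lower numbers stand for an effect already at smaller amounts and higher numbers for an effect only at larger amounts of compound), compound 1 gives > 100 mg/kg, which is a limit of the assay and not a number. Compound 3 `N=C(S)CCCCCCn1nc(-c2ccccc2)ccc1=O` extends that chain; in this assay compound 3 gives > 100 mg/kg, again a limit. Compound 2 `Cc1ccc(=O)n(CC(=N)S)n1` has a smaller core and the shortest chain; in this assay compound 2 gives > 100 mg/kg, also a limit. All three values share (the limit of > 100 mg/kg in this assay, at which 3 of the 3 values shown sit), so compound 1 stands nowhere readable: the step that the two limits leave unreadable from compound 1 to compound 3 cannot be sized.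

Compound 4 `CC(Cn1nc(-c2ccccc2)ccc1=O)C(=N)S` differs from compound 1 by a group of 5 heavy atoms (3 carbon, 1 nitrogen, 1 sulfur; no ring) in place of a group of 6 heavy atoms (4 carbon, 1 nitrogen, 1 sulfur; no ring), on a saturated chain carbon bound to an aromatic nitrogen. Within the data shown here, the only measured step that bears on such a chain change is the one from compound 1 to compound 3, and it is unreadable; no direction can be drawn from it. The expected step that the limit leaves unreadable from compound 1 to compound 4 is therefore taken as none beyond the scatter, with the limit itself the most likely outcome. Compound 4 is expected to give 150 mg/kg, between 60 mg/kg and 400 mg/kg.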

Compound 4, dose for half-maximal effect: 28.1 mg/kg
The estimate for compound 4 lay 5.3-fold (0.73 log units) above the measured number; the measured number lies below the stated range.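

Exchanging the group of 6 heavy atoms for the group of 5 heavy atoms, on a saturated chain carbon bound to an aromatic nitrogen, gives an at least 3.5-fold lower number from compound 1 to compound 4 (0.55 log units; beyond the scatter) in this assay. Among these compounds, this is the first sign that a change at this position can bring a value off the limit, which the earlier compounds did not show. The step is only a minimum, and the earlier step between chain lengths cannot be read: the limit of > 100 mg/kg in this assay, at which 3 of the 4 values shown sit.

The compounds shown leave open whether the read-out follows the size of this group or its shape, and whether the same group on the core of compound 2 would also come off the limit. From the compounds shown here alone, how an amine or a carboxylic acid would read in place of the group of 5 heavy atoms also remains open.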